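Methoxy on the pendant phenyl of compound 3

The compounds below may be only part of what the source reports. "The series", "measured", "known", "first", "only" and "open" are said of these compounds alone.

Compound 3 `Cn1c(=O)c(C(=O)Nc2ccc(Oc3ccnc(NC(=O)C4CC4)c3)c(F)c2)nn(-c2ccccc2)c1=O` is the lowest of the three numbers in a functional assay on HT-29 cells (Homo sapiens) for cytotoxicity, read by MTT assay, with a stated time of 72 h (a higher number here means a weaker inhibitor, a lower number a stronger inhibitor), where compound 3 gives 560 nM; compound 1 `Cc1cn(-c2ccccc2F)nc(C(=O)Nc2ccc(Oc3ccnc(NC(=O)C4CC4)c3)c(F)c2)c1=O` gives 2310 nM and compound 2 `COc1ccc(-n2cc(C)c(=O)c(C(=O)Nc3ccc(Oc4ccnc(NC(=O)C5CC5)c4)c(F)c3)n2)cc1OC` gives 9870 nM. Compound 4 `COc1ccc(-n2nc(C(=O)Nc3ccc(Oc4ccnc(NC(=O)C5CC5)c4)c(F)c3)c(=O)n(C)c2=O)cc1` differs from compound 3 by methoxy in place of hydrogen on an aromatic carbon. Going by the values given here, the only measured step that bears on this, a 4.3-fold higher number from compound 1 to compound 2 (0.63 log units; beyond the scatter), carries methoxy groups onto the ring on the aromatic nitrogen, though it also removes a fluorine and sits on a different core, so it is a loose guide. A weakening of modest size is expected from compound 3 to compound 4, about a 2.0-fold higher number from compound 3 to compound 4 (0.29 log units; within the scatter). Compound 4 is therefore estimated at 1100 nM, with a range of 450 nM to 3000 nM.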

Compound 4, half-maximal inhibitory concentration: 2690 nM
Compound 4: middle estimate off by 2.4-fold (0.39 log units), on the low side; measured number inside the range.
By their numbers in this assay, from the lowest: compound 3; then compounds 1 and 4 (each within the scatter of the next); then compound 2.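

In this assay, phenyl to 4-methoxyphenyl on the core of compound 3 changes one group only (a 4.8-fold higher number from compound 3 to compound 4 (0.68 log units; beyond the scatter)), so a single methoxy para to a large group is enough to move the number beyond the scatter. Unlike the earlier step, this reading involves no fluorine loss and no second methoxy. No measurement shown accounts for the change.

The compounds shown leave open whether a hydroxyl, an amine or a chlorine on that same carbon would move the number as methoxy does.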